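Working notes: the step from compound 3 to compound 4

The source may report more compounds than this note shows. Statements on the series, on what has been measured and on what is new or still open speak of the compounds shown alone.

Measured in an ADME assay on NIH3T3 cells (Mus musculus) for cytotoxicity; a higher number here means that more compound is needed for the effect, a lower number that less compound is needed:
compound 1 `Cc1cc(Oc2cccc(Cn3ccnn3)c2)cc(C)c1Cl`: 66800 nM
compound 2 `Cc1cc(Oc2cccc(Cn3cccn3)c2)cc(C)c1Cl`: > 100000 nM (a limit)
compound 3 `Cc1cc(Oc2cccc(Cn3nccn3)c2)cc(C)c1Cl`: > 100000 nM (a limit)

Compound 3 has only a limit, > 100000 nM, and no number. For the series as a whole, the position is the limit of > 100000 nM in this assay, at which 2 of the 3 values shown sit.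

Compound 4 `Cc1nnc(Cc2cccc(Oc3cc(C)c(Cl)c(C)c3)c2)o1` carries 5-methyl-1,3,4-oxadiazol-2-yl in place of 2H-1,2,3-triazol-2-yl on a saturated chain carbon bound to an aromatic carbon.

Exchanges at this place give an at least 1.4-fold higher number from compound 1 to compound 2 (0.17 log units; that floor lies within the scatter) and an at least 1.4-fold higher number from compound 1 to compound 3 (0.17 log units; that floor lies within the scatter), both floors within the scatter, while a step that the two limits leave unreadable from compound 2 to compound 3 cannot be read. No step beyond the scatter is therefore expected in this assay, in either direction. The expected step is an at least 1.1-fold lower number from compound 3 to compound 4 (0.04 log units; that floor lies within the scatter). For compound 4 the estimate is 90000 nM, with an expected range of 45000 nM to 150000 nM.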

Compound 4, half-maximal effective concentration: 6200 nM
The estimate for compound 4 lay 15-fold (1.16 log units) above the measured number; measured number outside the range, below it.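

In this assay this position now shows steps beyond the scatter: an at least 16-fold lower number from compound 3 to compound 4 (1.20 log units; beyond the scatter) and an at least 16-fold lower number from compound 2 to compound 4 (1.20 log units; beyond the scatter) and an 11-fold lower number from compound 1 to compound 4 (1.03 log units; beyond the scatter). Within the data shown here, the exchanges among compounds 1, 2 and 3 gave only floors within the scatter or unreadable steps, so 5-methyl-1,3,4-oxadiazol-2-yl is the first group here to separate clearly from the others. Two of these three steps start from limits, not numbers: the limit of > 100000 nM in this assay, at which 2 of the 4 values shown sit.

On these data alone, whether the methyl or the oxadiazole ring carries the step stays open. As far as these compounds go, how an amine or a carboxylic acid would read on this saturated chain carbon also stays open.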